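A few compounds are considered here, and "the series" means these few. Any claim that something is new, unique, unknown or untested is made for them only; others in the source may bear on it.

Measured in a functional assay on HT-1080 cells (Homo sapiens) for antiproliferative activity, read by sulforhodamine B assay, with a stated time of 48 h; a higher number here means a weaker inhibitor, a lower number a stronger inhibitor:
compound 1 `CC(C)(C)C(=O)Nc1ccc(S(=O)(=O)Oc2ccccc2I)cc1` gives 2600 nM
compound 2 `CC(C)c1ccccc1OS(=O)(=O)c1ccc(NC(=O)NCC2CCCC2)cc1` gives 6000 nM

Compound 2 holds the highest number of the two measured in this assay; its nearest neighbour is compound 1, whose number is lower by a step beyond the usual scatter. Compound 3 `O=C(NCC1CCCC1)Nc1ccc(S(=O)(=O)Oc2ccccc2I)cc1` has not been measured. It differs from compound 2 in one place: iodo in place of isopropyl on an aromatic carbon. Among the measured compounds shown here, no measured pair isolates this change, so the expectation rests loosely on compound 1, which also carries iodo and gives 2600 nM. A modest step toward a lower number is expected, a 1.7-fold lower number from compound 2 to compound 3 (0.23 log units; within the scatter). Compound 3 is estimated at 3500 nM, within a range from 1400 nM to 9000 nM.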

Compound 3, half-maximal inhibitory concentration: 6100 nM
Beside the measured number, compound 3's estimate is 1.7-fold (0.24 log units) below it; the range from low to high includes it.
By their numbers in this assay, from the lowest: compound 1; then compounds 2 and 3 (each within the scatter of the next).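

In this assay, iodo and isopropyl on this aromatic carbon cannot be told apart with the (cyclopentylmethyl)amino group in place (a 1.0-fold higher number from compound 2 to compound 3 (0.01 log units; within the scatter)). The step beyond the scatter comes instead from (cyclopentylmethyl)amino in place of tert-butyl on a carbonyl carbon, with iodo held fixed (a 2.3-fold higher number from compound 1 to compound 3 (0.37 log units; beyond the scatter)). No measured finding here accounts for either step.

From the compounds shown here alone, whether an amine or a carboxylic acid on this aromatic carbon would give a clearly different number stays open. So does whether iodo and isopropyl also match when tert-butyl sits on the carbonyl carbon.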